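A few compounds are considered here, and "the series" means these few. Any claim that something is new, unique, unknown or untested is made for them only; others in the source may bear on it.

Compound 1 `COc1ccc(-c2cn3ccnc3c(-c3ccc4ncn(C5CCCCC5)c4c3)n2)cc1`: 68.4%
Compound 2 `O=Cc1ccc(-c2cn3ccnc3c(-c3ccc4ncn(C5CCCCC5)c4c3)n2)cc1`: 14.4%
Compound 3 `c1cn2cc(-c3ccsc3)nc(-c3ccc4ncn(C5CCCCC5)c4c3)c2n1`: 0.39%

The three compounds share one core and differ only in the aromatic group attached to it. In a functional assay on SNB-19 cells (Homo sapiens) for inhibition, read by sulforhodamine B assay, with a stated time of 48 h, tested at 10 uM (a higher number here means more inhibition at the concentration tested (going by the name of the read-out), a lower number less inhibition), compound 3 gives 0.39%, the lowest of the three numbers. Its nearest neighbour is compound 2, reached by a number 14 percentage points lower from compound 2 to compound 3 (beyond the scatter), and its furthest is compound 1, reached by a number 68 percentage points lower from compound 1 to compound 3 (beyond the scatter).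

Compound 4 `FC(F)(F)c1cccc(-c2cn3ccnc3c(-c3ccc4ncn(C5CCCCC5)c4c3)n2)c1` carries a different aromatic group: 3-(trifluoromethyl)phenyl in place of thiophen-3-yl on an aromatic carbon. Both measured steps into compound 3 replaced a phenyl-type ring with thiophen-3-yl and lowered the inhibition, one by a large amount, the other by a modest one. The step to compound 4 runs the other way, putting a phenyl-type ring back, so a rise is expected. How much depends on the group on that ring, and trifluoromethyl is neither methoxy nor formyl, so the size is uncertain. The expected step is a number 34.6 percentage points higher from compound 3 to compound 4 (beyond the scatter). Compound 4 is estimated at 35%, within 5% to 75%.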

Compound 4, a percentage reported as inhibition, at one concentration (the size of the read-out at that concentration, not a potency): 2.24%
Compound 4: middle estimate off by 32.8 percentage points, on the high side, outside the stated range (below it).
By their numbers in this assay, from the lowest: compounds 3 and 4 (each within the scatter of the next); then compound 2; then compound 1.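

In this assay a phenyl ring at this position does not by itself bring inhibition back: the step is a number 1.9 percentage points higher from compound 3 to compound 4 (within the scatter) and so thiophen-3-yl and 3-(trifluoromethyl)phenyl cannot be told apart here. Against the other two phenyl compounds the steps are a number 12.2 percentage points lower from compound 2 to compound 4 (beyond the scatter) and a number 66.2 percentage points lower from compound 1 to compound 4 (beyond the scatter) so the high number of compound 1 belongs to 4-methoxyphenyl and not to just any phenyl ring.

On these data alone, compound 4 differs from compound 1 and compound 2 both in the group on the ring and in where that group sits, so these two changes cannot be separated, and it remains open whether an amine or a longer ether chain in place of methoxy would keep the inhibition. Nothing available gives a reason for these differences.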